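The source may hold more compounds than are shown below. What is called first, only, known or untested is meant among the compounds shown, and "the series" means these compounds.

Measured compounds:
Compound 1, `C[C@@]1(c2cc(NC(=O)c3coc(CF)n3)ccc2F)C=C(CF)OC(N)=N1`: 55 mL/min/kg
Compound 2, `C[C@@]1(c2cc(NC(=O)c3cnc(OCF)cn3)ccc2F)C=C(CF)OC(N)=N1`: 34.4 mL/min/kg
Compound 3, `COCC1=C[C@@](C)(c2cc(NC(=O)c3ccc(C#N)cn3)ccc2F)N=C(N)O1`: 12.9 mL/min/kg

In an ADME assay on the whole organism (strain Sprague-Dawley) for pharmacokinetics, with Rattus norvegicus as the target, read by LC-MS, using cassette dosing, at a dose of 0.5 mg/kg by the intravenous route (a higher number here means faster removal of the compound, a lower number slower removal), compound 2 stands second highest of the three numbers, close to compound 1 and well apart from compound 3. Compound 4 `COc1cc(C#N)cnc1C(=O)Nc1ccc(F)c([C@]2(C)C=C(CF)OC(N)=N2)c1` has not yet been measured; it differs from compound 2 in one place, (5-cyano-3-methoxypyridin-2-yl in place of 5-(fluoromethoxy)pyrazin-2-yl on a carbonyl carbon). Within the data shown here, the one measured step, a 1.6-fold lower number from compound 1 to compound 2 (0.20 log units; within the scatter), also changes the group on the carbonyl carbon but does not involve the entering group, so it bears on the new step only loosely. Compound 3, which carries a cyanopyridinyl group on its carbonyl carbon together with a different core, gives 12.9 mL/min/kg in this assay. Weighing this, compound 4 is expected to show a moderate decrease, a 1.7-fold lower number from compound 2 to compound 4 (0.24 log units; within the scatter), possibly within the scatter. The estimate for compound 4 is 20 mL/min/kg, with a range from 9 mL/min/kg to 45 mL/min/kg.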

Compound 4, clearance: 36.6 mL/min/kg
Estimate against measurement, compound 4: 1.8-fold (0.26 log units) below, and the stated range covers the measured number.
By their numbers in this assay, from the lowest: compound 3; then compounds 2, 4 and 1 (each within the scatter of the next).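

In this assay, 5-cyano-3-methoxypyridin-2-yl in place of 5-(fluoromethoxy)pyrazin-2-yl on the carbonyl carbon gives a 1.1-fold higher number from compound 2 to compound 4 (0.03 log units; within the scatter), and in place of 2-(fluoromethyl)-1,3-oxazol-4-yl it gives a 1.5-fold lower number from compound 1 to compound 4 (0.18 log units; within the scatter). On the shared core, all three groups at this position therefore lie within the scatter of one another, including the one that brings a nitrile and drops the fluorine. Nothing available explains this result.

As far as these compounds go, it remains open whether any group at this position moves clearance beyond the scatter on this core, such as an amine or a carboxylic acid on the aromatic ring. From the compounds shown here alone, the separate contributions of the cyano and methoxy groups also remain open.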